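The source may hold more compounds than are shown below. What is called first, only, known or untested is meant among the compounds shown, and "the series" means these compounds.

Three compounds have been measured so far in a functional assay on A-375 cells (Homo sapiens) for inhibition, read by CCK-8 assay, with a stated time of 72 h, tested at 8 uM (a higher number here means more inhibition of growth at the concentration tested, a lower number less inhibition of growth), with these results:

compound 1 `Cc1cc(C)cc(SCc2ccc(/C=C/C(=O)Nc3ccccc3N)cc2)c1` gives 2.49%
compound 2 `Nc1ccccc1NC(=O)c1ccc(CSc2ccc(Br)cc2)cc1` gives 6.17%
compound 3 `Nc1ccccc1NC(=O)c1ccc(CSc2ccc(C(F)(F)F)cn2)cc1` gives 5.34%

Compound 1 stands level with the other two, since the values of compound 2 and compound 3 both lie within the usual scatter of its value. The three numbers therefore show no order among these compounds.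

Compound 4 `Nc1ccccc1NC(=O)/C=C/c1ccc(CSCCc2ccccc2)cc1` has not yet been measured. For the measured compounds named here, it has the same atoms as compound 1, joined differently, with phenethyl in place of 3,5-dimethylphenyl on a sulfur as the one change. Going by the values given here, no step between measured compounds that differ in one place is available, so the data give no direct size for such a change.

Since compound 1 at 2.49% sits with the other two at a low level, no step beyond the scatter is expected in this assay in either direction. The estimated change is a number 3.5 percentage points higher from compound 1 to compound 4 (within the scatter) and would stay within the scatter. For compound 4 the estimated inhibition is 6% with an expected range of 0% to 20% across repeat measurements.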

Compound 4, percent growth inhibition at one concentration: 37.4%
The estimate for compound 4 lay 31.4 percentage points below the measured number; measured number above the stated range.
By their numbers in this assay, from the lowest: compounds 1, 3 and 2 (each within the scatter of the next); then compound 4.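

In this assay, the group on a sulfur whose other neighbour is a saturated chain carbon proves able to move the result well beyond the scatter, which the three earlier compounds, all level with each other, could not show. Phenethyl in place of 3,5-dimethylphenyl gives a number 34.9 percentage points higher from compound 1 to compound 4 (beyond the scatter), although both groups have the same heavy-atom count, one six-membered aromatic ring of carbon only, no hydrogen-bond donors or acceptors and no net charge. Nothing shown here accounts for this step.

The compounds shown leave open whether benzyl or a longer chain such as 3-phenylpropyl on this sulfur would hold this level, and whether an amine or a carboxylic acid on the phenethyl ring would change it. They also leave open whether phenethyl would give a similar step on the core of compound 2.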